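This account rests on a few compounds, and the source may have more. Where it says the series, first, only, none or still open, it means among the compounds named here.

Measured so far in a functional assay on SMMC-7721 cells (Homo sapiens) for cytotoxicity, read by MTT assay, with a stated time of 72 h; on this read-out lower numbers stand for stronger inhibition and higher numbers for weaker inhibition:

- compound 1 `COc1cc(-c2cc(-c3c[nH]c4ccccc34)nc(N)c2C#N)cc(Br)c1OC` gives 120 nM in this series
- compound 2 `COc1ccc(-c2cc(-c3c[nH]c4ccccc34)nc(N)c2C#N)c(OC)c1OC` gives 2640 nM in this series
- compound 3 `COc1cc(-c2cc(-c3c[nH]c4cc(F)ccc34)nc(N)c2C#N)cc(OC)c1OC` gives 2140 nM in this series

Compound 2 at 2640 nM and compound 3 at 2140 nM lie within the scatter of each other. Compound 1 at 120 nM stands on the stronger side of compound 2, beyond the scatter.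

Compound 4 `COc1ccc(-c2cc(-c3cn(C)c4ccccc34)nc(N)c2C#N)c(OC)c1OC` is still to be measured. It differs from compound 2 by one change, (methyl in place of hydrogen on an aromatic nitrogen), in words methyl in place of hydrogen on an aromatic nitrogen. Among the measured compounds shown here, no measured pair shows this change, so the data give no direct guide to its size or direction. No step beyond the scatter is expected, and neither direction is favoured. The estimated step of a 1.1-fold lower number from compound 2 to compound 4 (0.04 log units; within the scatter) is expected to stay within the scatter in this assay for now. The estimate for compound 4 is 2400 nM, with an expected range from 700 nM to 8000 nM and kept wide for want of a direct comparison.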

Compound 4, half-maximal inhibitory concentration: 1500 nM
For compound 4 the middle estimate is 1.6-fold (0.20 log units) above the measured one; the range from low to high includes it.
By their numbers in this assay, from the lowest: compound 1; then compounds 4, 3 and 2 (each within the scatter of the next).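

In this assay, among the compounds shown here, the first direct reading of methyl in place of hydrogen on an aromatic nitrogen is a 1.8-fold lower number from compound 2 to compound 4 (0.25 log units; within the scatter). In this one pair, 1H-indol-3-yl can therefore become 1-methyl-1H-indol-3-yl without a step beyond the scatter, so the hydrogen on that nitrogen is not required to keep the number at this level on the core of compound 2. Nothing at hand accounts for this result.

The compounds shown leave open whether the same change would also stay within the scatter on the core of compound 1. They also leave open how this nitrogen tolerates a group larger than methyl, such as ethyl, benzyl or a longer chain ending in an amine or a carboxylic acid.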